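The source may hold more compounds than are shown below. What is called first, only, known or untested is meant among the compounds shown, and "the series" means these compounds.

Within the data shown here, in an ADME assay on the whole organism (Rattus norvegicus) for pharmacokinetics, at a dose of 0.5 mg/kg by the intravenous route (on this read-out higher numbers stand for fast clearance and lower numbers for slow clearance), compound 2 `CC1CN(c2cnc3cnn(C(C)c4ccc(Cl)cc4Cl)c3n2)CCC1N1CCCCC1` gives 122 mL/min/kg, the higher of the two numbers so far, while compound 1 `CC1CN(c2cnc3c(C(F)(F)F)nn(C(C)c4ccc(Cl)cc4Cl)c3n2)CCC1N1CCCCC1` gives 56.7 mL/min/kg. Compound 3 `CC1CN(c2cnc3c(C(N)=O)nn(C(C)c4ccc(Cl)cc4Cl)c3n2)CCC1N1CCCCC1` differs from compound 2 by carbamoyl in place of hydrogen on an aromatic carbon, with carbamoyl in place of hydrogen on an aromatic carbon. Among the measured compounds shown here, one measured step bears on this carbon: hydrogen in place of trifluoromethyl gave a 2.2-fold higher number from compound 1 to compound 2 (0.33 log units; beyond the scatter), a modest change. Carbamoyl is a different group, so the parallel is loose, but a step of similar size towards a lower number is expected, a 2.0-fold lower number from compound 2 to compound 3 (0.31 log units; beyond the scatter). For compound 3 the estimate is 60 mL/min/kg, with an expected range of 30 mL/min/kg to 115 mL/min/kg.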

Compound 3, clearance: 102 mL/min/kg
For compound 3 the middle estimate is 1.7-fold (0.23 log units) below the measured one; the range from low to high includes it.
By their numbers in this assay, from the lowest: compounds 1, 3 and 2 (each within the scatter of the next, the first and the last beyond it).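

In this assay, carbamoyl on this aromatic carbon gives a 1.2-fold lower number from compound 2 to compound 3 (0.08 log units; within the scatter) and so does not separate from hydrogen, whereas trifluoromethyl at the same carbon did. The exchange of trifluoromethyl for carbamoyl gives a 1.8-fold higher number from compound 1 to compound 3 (0.26 log units; within the scatter) and so does not separate those two groups either, which places carbamoyl within the scatter of both. No supporting data explain this outcome. Going by these compounds, whether a nitrile, a carboxylic acid or a methyl group on this carbon would stand apart from hydrogen remains open, as does the effect of replacing an amide hydrogen with a methyl group.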